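The source may report more compounds than this note shows. Statements on the series, on what has been measured and on what is new or still open speak of the compounds shown alone.

In a functional assay on CCRF-CEM cells (Homo sapiens) for antiproliferative activity, with a stated time of 72 h (a lower number here means a stronger inhibitor, a higher number a weaker inhibitor), two compounds with a shared core have been measured so far. Compound 1 `OC[C@H]1O[C@@H](n2cnc3c(NCc4ccccc4Cl)ncnc32)[C@H](O)[C@@H]1O`, with a chloro group on its aromatic ring, gives 14500 nM, while compound 2 `COc1ccccc1CNc1ncnc2c1ncn2[C@@H]1O[C@H](CO)[C@@H](O)[C@H]1O`, with a methoxy group in its place, gives 3200 nM. Compound 2 thus has the lower number of the two and is the stronger inhibitor.

Compound 3 `OC[C@H]1O[C@@H](n2cnc3c(NCc4ccccc4OC(F)(F)F)ncnc32)[C@H](O)[C@@H]1O` has not yet been measured. It turns methoxy into trifluoromethoxy, with trifluoromethyl in place of methyl on an oxygen on an aromatic ring. Among the compounds with values here, only one measured step bears on this, the modest change of a 4.5-fold lower number from compound 1 to compound 2 (0.66 log units; beyond the scatter). Within the data shown here, that step swapped the whole group, and no measured pair tests a change on the oxygen itself, so it is only a loose guide. The one move away from methoxy seen so far leads to compound 1 at 14500 nM, so a move in that direction seems the likelier outcome. The expected change is a 1.9-fold higher number from compound 2 to compound 3 (0.27 log units; within the scatter), a step no larger than the measured one. For compound 3 the estimated value in this assay is 6000 nM, with an expected range of 2000 nM to 18000 nM.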

Compound 3, half-maximal inhibitory concentration: > 166000 nM
Compound 3 gave a limit, no number (the forecaster's own chance of this, stated with the estimate: 5%); at least 27-fold (1.44 log units) between middle value and limit.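

In this assay compound 3 gives a limit of the assay and not a number: the limit of > 166000 nM in this assay, at which 1 of the 3 values shown sits.

Even so, this limit shows something the earlier compounds could not, since they never tested a change on the oxygen itself: trifluoromethyl in place of methyl on an oxygen on an aromatic ring gives an at least 51-fold higher number from compound 2 to compound 3 (1.71 log units; beyond the scatter), a large step, where the earlier swap of chloro for methoxy gave only a modest 4.5-fold lower number from compound 1 to compound 2 (0.66 log units; beyond the scatter). The new group also compares poorly with chloro on the same aromatic carbon, with an at least 11-fold higher number from compound 1 to compound 3 (1.05 log units; beyond the scatter), so among these three compounds the trifluoromethoxy group is clearly the worst tolerated, and methoxy and trifluoromethoxy, though alike in name, are far from interchangeable at this place.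

The compounds shown leave open whether difluoromethoxy, ethoxy or a plain hydroxyl on this aromatic carbon would stay close to compound 2 or drop towards compound 3. They also cannot tell how far beyond the limit compound 3 really lies, or whether the same change would have a step of this size on another core.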